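Fluorine added to a phenyl ring in an antiproliferative series

The source may report more compounds than this note shows. Statements on the series, on what has been measured and on what is new or still open speak of the compounds shown alone.

Measured compounds:
- compound 1, `CNC(=O)c1cc(Oc2ccc(NC(=O)c3cc4cccnc4n(-c4ccccc4F)c3=O)cc2)ccn1`: 260 nM
- compound 2, `CCNC(=O)c1cc(Oc2ccc(NC(=O)c3cc4cccnc4n(-c4ccccc4)c3=O)cc2)ccn1`: 220 nM

In a functional assay on HT-29 cells (Homo sapiens) for antiproliferative activity, read by MTT assay, with a stated time of 72 h (on this read-out higher numbers stand for weaker inhibition and lower numbers for stronger inhibition), compound 1 gives 260 nM and compound 2 gives 220 nM. Compound 2 has the lowest of the two numbers, and compound 1 is its nearest neighbour, with a gap that lies within the scatter of the assay, so the two compounds cannot be told apart on these readings.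

The next compound, compound 3, `CCNC(=O)c1cc(Oc2ccc(NC(=O)c3cc4cccnc4n(-c4ccccc4F)c3=O)cc2)ccn1`, is compound 2 with one change: fluoro in place of hydrogen on an aromatic carbon. The new fluorine sits on an aromatic carbon of a six-membered ring of carbon only, ortho to a large group. Among the measured compounds shown here, no measured pair shows this single change on its own. Compound 1, which already carries the fluorine but a methyl amide instead of the ethyl amide, sits within the scatter of compound 2, which gives no hint of a large effect either way. The expected step in this assay from compound 2 to compound 3 is therefore small, a 1.1-fold higher number from compound 2 to compound 3 (0.04 log units; within the scatter), within the scatter. Compound 3 is estimated at 240 nM, with a range from 120 nM to 480 nM.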

Compound 3, half-maximal inhibitory concentration: 260 nM
For compound 3 the middle estimate is 1.1-fold (0.03 log units) below the measured one; measured number inside the range.
By their numbers in this assay, from the lowest: compounds 2, 1 and 3 (each within the scatter of the next).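

In this assay, the swap of phenyl to 2-fluorophenyl now has a direct reading, a 1.2-fold higher number from compound 2 to compound 3 (0.07 log units; within the scatter), so adding this fluorine on the ring leaves no difference that the assay can resolve. Compound 3 also isolates the amide end with the fluorine held in place: adding a methyl to the chain on the amide nitrogen gives no change at the digits printed from compound 1 to compound 3 (within the scatter), so the methyl amide and the ethyl amide cannot be told apart in this fluorinated pair. No accompanying measurement bears on why these two single changes give such small steps.

Going by these compounds, whether this ring carbon stays as undemanding with a larger or differently charged substituent, such as chloro, methoxy or an amine, remains open, as does the outcome of moving the fluorine to another carbon of the ring. At the other end of the molecule, a longer chain such as propyl on the amide nitrogen, or a carboxylic acid in place of the amide, could show whether that end matters more than these close neighbours suggest.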